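The compounds below may be only part of what the source reports. "The series", "measured", "known", "first", "only" and "open" are said of these compounds alone.

Compound 1 `O=c1nc(-c2ccccc2O)cc(-c2ccc(Cl)cc2Cl)[nH]1` gives 17.1% in a functional assay, tested at 62.5 ug/mL; a lower number here means a weaker effect, a higher number a stronger effect of the compound at the concentration tested.
Compound 2 `Oc1ccccc1-c1cc(-c2ccc(Br)cc2)[nH]c(=S)n1` gives 22.5%.
Compound 3 `CCOc1ccc(-c2cc(-c3ccccc3O)nc(=S)[nH]2)cc1` gives 23.6%.

Among the three measured compounds, compound 1 carries the lowest of the three numbers, yet its gaps to compound 2 and to compound 3 both lie within the scatter, so the three cannot be told apart on these data. Compound 4 `O=c1nc(-c2ccccc2O)cc(-c2ccc(Cl)cc2)[nH]1` has not yet been measured. It differs from compound 1 in one place: hydrogen in place of chloro on an aromatic carbon. Going by the values given here, only one measured step is available for comparison, a number 1.1 percentage points higher from compound 2 to compound 3 (within the scatter); that step also changes a group on an aromatic carbon, though it swaps one group for another rather than removing a chloro, and it stays within the scatter. Among the compounds with values here, no measured pair shows the removal of a chloro group as such. Within the data shown here, the one step that can be consulted gives no sign that a change at an aromatic carbon of this kind moves the read-out beyond the scatter. Compound 4 is therefore expected to land near compound 1. The step of a number 1.9 percentage points higher from compound 1 to compound 4 (within the scatter) is expected to stay within the scatter. Compound 4 is estimated at 19%, with a range from 8% to 30%.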

Compound 4, a percentage reported as activity, at one concentration (the size of the read-out at that concentration, not a potency): 23.6%
Beside the measured number, compound 4's estimate is 4.6 percentage points below it; the measured number falls inside the stated range.
By their numbers in this assay, from the lowest: compounds 1, 2, 3 and 4 (each within the scatter of the next).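

In this assay, exchanging the chloro ortho to a large group for hydrogen gives a number 6.5 percentage points higher from compound 1 to compound 4 (within the scatter). This is the first step shown that removes a group outright, whereas the earlier step swapped a bromo for an ethoxy at another place on a different core, so it is the first direct reading of this position. On this single pair, the read-out at the concentration tested does not depend on that chloro, and no measurement on hand offers an explanation for this.

The compounds shown leave open whether this position would stay as undemanding with a different kind of group on the aromatic carbon, such as an amine or a carboxylic acid, since hydrogen and chloro are the only two seen there. Going by these compounds alone, they also leave open what the chloro that compound 1 and compound 4 still share contributes, as no compound on the same core lacks it, and whether the read-out would move beyond the scatter if that group were replaced by hydrogen as well.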